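Methoxy on the Aryl Ring: Expected Cytotoxicity of Compound 4

This account rests on a few compounds, and the source may have more. Where it says the series, first, only, none or still open, it means among the compounds named here.

Measured in a toxicity assay on HeLa cells (Homo sapiens) for cytotoxicity, read by MTT assay, with a stated time of 24 h; a higher number here means a weaker inhibitor, a lower number a stronger inhibitor:
compound 1 `CCOC(=O)N1CCN(C(=S)SCC(O)Cn2c([N+](=O)[O-])cnc2C)CC1` gives 1610000 nM
compound 2 `CCN1CCN(C(=S)SCC(O)Cn2c([N+](=O)[O-])cnc2C)CC1` gives > 5000000 nM
compound 3 `Cc1ncc([N+](=O)[O-])n1CC(O)CSC(=S)N1CCN(c2ccccc2)CC1` gives > 5000000 nM

Compound 1 is the only one of the three with a number. For compound 2 the assay returns only a limit, > 5000000 nM. For compound 3 it likewise returns only a limit, > 5000000 nM, so compound 3 stands at the top of the range shown, at the same limit as compound 2 (the limit of > 5000000 nM in this assay, at which 2 of the 3 values shown sit). The step of an at least 3.1-fold higher number from compound 1 to compound 3 (0.49 log units; beyond the scatter) and the step of an at least 3.1-fold higher number from compound 1 to compound 2 (0.49 log units; beyond the scatter) are readable only as lower bounds, and the step that the two limits leave unreadable from compound 2 to compound 3 cannot be read at all.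

Compound 4 `COc1ccccc1N1CCN(C(=S)SCC(O)Cn2c([N+](=O)[O-])cnc2C)CC1` differs from compound 3 by methoxy in place of hydrogen on an aromatic carbon. Going by the values given here, none of the measured steps touches the aryl group itself; the two readable steps only show that compounds 2 and 3 sit well away from compound 1. Because compound 3 already gives > 5000000 nM, there is no measured footing for predicting movement in either direction. The step of a number no higher from compound 3 to compound 4 (the limit leaves the size open) is therefore expected to be none beyond the scatter. Compound 4 is expected at 5000000 nM, between 2000000 nM and 12000000 nM, most likely reported again only as a limit.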

Compound 4, half-maximal inhibitory concentration: > 5000000 nM
Compound 4: only a limit was reported; the forecaster's own chance of this, stated with the estimate: 70%; the middle value sits exactly at the limit.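

In this assay compound 4 gives > 5000000 nM, which is a limit of the assay and not a number. Methoxy on an aromatic carbon, ortho to a large group, thus brings no measured value into range, and the limit now takes in one more compound: the limit of > 5000000 nM in this assay, at which 3 of the 4 values shown sit. The one readable step, an at least 3.1-fold higher number from compound 1 to compound 4 (0.49 log units; beyond the scatter), is a lower bound, while the steps among the three compounds held at the limit cannot be read.

From the compounds shown here alone, whether any group on the aryl ring can bring a compound back into measurable range remains open. What an amine or a carboxylic acid on that ring would do, or a longer chain in place of ethoxycarbonyl, is also unknown from these compounds.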